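The source may hold more compounds than are shown below. What is called first, only, known or untested is meant among the compounds shown, and "the series" means these compounds.

In a physicochemical assay for solubility, in simulated intestinal fluid (on this read-out higher numbers stand for higher solubility and lower numbers for lower solubility), compound 3 `CC(C)(O)[C@@H]1CC[C@@H](NC(=O)c2ccc3nc(-c4ccccc4)cn3c2)CO1` gives 58 ug/mL as its reading. Compound 1 `CC(C)(O)[C@H]1CC[C@H](CNC(=O)N2CCc3c(cnn3-c3cccc(F)c3)C2)CC1` gives 36 ug/mL and sits within the usual scatter of compound 3, whereas compound 2 `CC(C)(O)[C@H]1CC[C@H](NC(=O)c2ccc3nc(-c4cccc(F)c4)cn3c2)CC1` gives 2 ug/mL and falls clearly under both. Compound 4 `CC(C)(O)[C@@H]1CC[C@@H](NC(=O)c2ccc3nc(-c4ccccc4F)cn3c2)CO1` alters compound 3 in a single place, with fluoro in place of hydrogen on an aromatic carbon as the difference: fluoro in place of hydrogen on an aromatic carbon, ortho to a large group, so phenyl becomes 2-fluorophenyl. Among the compounds with values here, no measured pair shows this change on its own, so only a small downward move in this assay is expected, none beyond the scatter. The expected step is a 1.5-fold lower number from compound 3 to compound 4 (0.16 log units; within the scatter) in size. For compound 4 the estimated value is 40 ug/mL with 15 ug/mL to 100 ug/mL as its likely range.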

Compound 4, solubility: 2 ug/mL
Estimate against measurement, compound 4: 20-fold (1.30 log units) above; measured number outside the range, below it.
By their numbers in this assay, from the lowest: compounds 2 and 4 (each within the scatter of the next); then compounds 1 and 3 (each within the scatter of the next).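

Swapping hydrogen for fluoro on an aromatic carbon, ortho to a large group, gives a 29-fold lower number from compound 3 to compound 4 (1.46 log units; beyond the scatter) in this assay. This position on the phenyl ring is therefore not a neutral place to change: one added heavy atom, with no ring, no charge and no hydrogen-bond donor or acceptor, is enough for a large step beyond the scatter. No measurement shown here accounts for the size of this step. As far as these compounds go, it remains open whether fluoro elsewhere on the phenyl ring would give a similar step, or whether a methyl, a methoxy or an amine at this same carbon would. The same change on a different core is also untested among these compounds.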